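The source may hold more compounds than are shown below. What is called first, only, known or untested is meant among the compounds shown, and "the series" means these compounds.

In a functional assay on HepG2 cells (Homo sapiens) for cytotoxicity, read by MTT assay, with a stated time of 24 h (a higher number here means a weaker inhibitor, a lower number a stronger inhibitor), compound 1 `CN1C/C(=C\c2ccncc2)C(=O)/C(=C/c2ccccc2F)C1` gives 4600 nM. Compound 2 `O=C1/C(=C/c2ccncc2)CNC/C1=C\c1ccccc1F` gives 8200 nM, which lies within the scatter of compound 1. Compound 3 `O=C1/C(=C/c2ccncc2)CN(S(=O)(=O)c2ccccc2)C/C1=C\c1ccccc1F` differs from compound 2 by phenylsulfonyl in place of hydrogen on an amine nitrogen in a ring, with phenylsulfonyl in place of hydrogen on an amine nitrogen in a ring. Within the data shown here, the only measured step at that nitrogen, a 1.8-fold higher number from compound 1 to compound 2 (0.25 log units; within the scatter), is small and involves methyl, so it offers only weak guidance. In this assay a modest step toward a lower number is therefore expected, with no change beyond the scatter also possible. The estimate is a 1.8-fold lower number from compound 2 to compound 3 (0.26 log units; within the scatter). For compound 3 the estimated value is 4500 nM, within a range of 1300 nM to 15000 nM.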

Compound 3, half-maximal inhibitory concentration: 5800 nM
For compound 3 the middle estimate is 1.3-fold (0.11 log units) below the measured one; measured number inside the range.
By their numbers in this assay, from the lowest: compounds 1, 3 and 2 (each within the scatter of the next).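

In this assay, phenylsulfonyl on the amine nitrogen in the ring, with its 9 heavy atoms, stays within the scatter of both smaller groups: the change from hydrogen gives a 1.4-fold lower number from compound 2 to compound 3 (0.15 log units; within the scatter), and the change from methyl gives a 1.3-fold higher number from compound 1 to compound 3 (0.10 log units; within the scatter). Hydrogen, methyl and phenylsulfonyl at this nitrogen are therefore not told apart in this cell assay. No evidence bearing on this result is available. Going by these compounds, it remains open whether an acetyl or benzyl group at this nitrogen would move the number beyond the scatter.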